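The source may report more compounds than this note shows. Statements on the series, on what has been measured and on what is new or still open speak of the compounds shown alone.

Compound 1 `O=C(N/N=C/c1cccc(Cl)c1Cl)Nc1cc2c(Nc3ccc(F)c(Cl)c3)ncnc2cc1O[C@H]1CCOC1`: 25000 nM
Compound 2 `COc1cc2ncnc(Nc3ccc(F)c(Cl)c3)c2cc1NC(=O)N/N=C/c1cccc(Cl)c1Cl`: 35300 nM

Both were measured in a functional assay on A549 cells (Homo sapiens) for cytotoxicity, read by MTT assay, with a stated time of 72 h; a higher number here means a weaker inhibitor, a lower number a stronger inhibitor. Where compound 2 stands relative to compound 1 is told by a 1.4-fold higher number from compound 1 to compound 2 (0.15 log units; within the scatter), which leaves the two compounds indistinguishable. Compound 3 `CCN(CC)c1ccc(/C=N/NC(=O)Nc2cc3c(Nc4ccc(F)c(Cl)c4)ncnc3cc2OC)c(O)c1` differs from compound 2 by 4-(diethylamino)-2-hydroxyphenyl in place of 2,3-dichlorophenyl on a carbon with a double bond to nitrogen. Within the data shown here, the one measured step concerns the group on the oxygen on the aromatic ring, not the carbon with a double bond to nitrogen, so it does not bear on this change. Among the measured compounds shown here, with no guiding step, compound 3 is expected to give 30000 nM, in a range from 8000 nM to 100000 nM. The expected step is a 1.2-fold lower number from compound 2 to compound 3 (0.07 log units; within the scatter), none beyond the scatter, though the range is wide.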

Compound 3, half-maximal inhibitory concentration: 27300 nM
Compound 3: the middle estimate sits 1.1-fold (0.04 log units) above what was measured, within the range that was stated.
By their numbers in this assay, from the lowest: compounds 1, 3 and 2 (each within the scatter of the next).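

Replacing 2,3-dichlorophenyl with 4-(diethylamino)-2-hydroxyphenyl on the carbon with a double bond to nitrogen gives a 1.3-fold lower number from compound 2 to compound 3 (0.11 log units; within the scatter) in this assay and leaves the two compounds indistinguishable. Among these compounds, this is the first measured step at this position, and it shows that two quite different substituted phenyl groups can occupy it without separating the compounds in this assay. Nothing measured here explains this result.

As far as these compounds go, it remains open whether a phenyl carrying only diethylamino or only hydroxy, or an amine or carboxylic acid in place of the phenyl, would separate from these compounds. From the compounds shown here alone, it is also open whether 4-(diethylamino)-2-hydroxyphenyl would give the same result with oxolan-3-yl on the oxygen.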